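A propyl chain in place of an amino group

This account rests on a few compounds, and the source may have more. Where it says the series, first, only, none or still open, it means among the compounds named here.

Of the compounds shown here, three sharing one core have been measured in a functional assay (spleen, spleen) for activation, with Mus musculus as the target; a lower number here means that less compound is needed, a higher number that more compound is needed for the effect. Compound 1 `CCCSc1nc(N)c2nc(O)n(Cc3ccccc3)c2n1` gives 0.01 uM in this assay. Compound 2 `CCCCCNc1nc(N)c2nc(O)n(Cc3ccccc3)c2n1` gives 0.1 uM in this assay. Compound 3 `Nc1nc(N)c2nc(O)n(Cc3ccccc3)c2n1` gives 10 uM in this assay, the highest of the three numbers, with compound 2 as its nearest neighbour and compound 1 as its furthest.

The unmeasured compound 4 `CCCc1nc(N)c2nc(O)n(Cc3ccccc3)c2n1` differs from compound 3 at a single aromatic carbon. propyl in place of amino on an aromatic carbon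

Within the data shown here, two measured steps bear on this change. Going from compound 1 to compound 3 removed a three-carbon chain bearing sulfur and gave a 1000-fold higher number from compound 1 to compound 3 (3.00 log units; beyond the scatter). Going from compound 2 to compound 3 removed a five-carbon chain from a ring nitrogen and gave a 100-fold higher number from compound 2 to compound 3 (2.00 log units; beyond the scatter). Both show that replacing a chain at this position by a small group without carbon raised the number by a large amount; compound 4 reverses that direction by putting a chain back.

Compound 4 is therefore expected to give a large step down in this assay, a 100-fold lower number from compound 3 to compound 4 (2.00 log units; beyond the scatter). The estimate for compound 4 is 0.1 uM, with a range from 0.01 uM to 1 uM.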

Compound 4, minimum effective concentration: 1 uM
Compound 4: middle estimate off by 10-fold (1.00 log units), on the low side; the measured number falls inside the stated range.
By their numbers in this assay, from the lowest: compound 1; then compound 2; then compound 4; then compound 3.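

In this assay a propyl chain joined directly to the aromatic carbon still gives a 10-fold lower number from compound 3 to compound 4 (1.00 log units; beyond the scatter) and so the fall in the number does not depend entirely on a sulfur or nitrogen link to the core. The link counts too: with the propyl chain kept and only the sulfur lost, the change gives a 100-fold higher number from compound 1 to compound 4 (2.00 log units; beyond the scatter) and this is the cleanest reading at this position, since the two groups differ by that one atom. Pentylamino exchanged for propyl gives a 10-fold higher number from compound 2 to compound 4 (1.00 log units; beyond the scatter) but there the link and the chain length change together, and the data offer no explanation for any of these differences.

A propylamino group would separate the effect of the nitrogen link from that of chain length, and pentyl joined directly to the carbon would show whether a longer chain alone can narrow the gap to compound 1. Going by these compounds, whether propoxy, with oxygen as the link, or pentylsulfanyl, with a longer chain on sulfur, would bring the number lower still remains open.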